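Bromo for fluoro on the fused ring of compound 3

The source may report more compounds than this note shows. Statements on the series, on what has been measured and on what is new or still open speak of the compounds shown alone.

Compound 1 `COc1ccccc1NC(=O)NC1CC(C)(C)Oc2ccc(Br)cc21`: in a functional assay (aorta) with Rattus norvegicus as the target (a higher number here means that more compound is needed for the effect, a lower number that less compound is needed), compound 1 gives > 10000 nM, a limit of the assay.
Compound 2 `COc1cccc(NC(=O)NC2CC(C)(C)Oc3ccc(Br)cc32)c1`: in this assay compound 2 gives > 10000 nM, again a limit.
Compound 3 `Cc1ccccc1NC(=O)NC1CC(C)(C)Oc2ccc(F)cc21`: in this assay compound 3 gives > 30000 nM, also a limit.

Compound 3 therefore stands only at a limit, and no number is known for any of the three. Among the compounds with values here, the sole measured step, a step that the two limits leave unreadable from compound 1 to compound 2, is unreadable, as both ends sit at the limit of > 10000 nM in this assay, at which 2 of the 3 values shown sit. Compound 4 `Cc1ccccc1NC(=O)NC1CC(C)(C)Oc2ccc(Br)cc21` carries bromo in place of fluoro on an aromatic carbon. Within the data shown here, no measured step bears on this change, and the sole one available is itself unreadable. The expectation for compound 4 in this assay is a further limit rather than a number, with an estimated step of a number no higher from compound 3 to compound 4 (the limit leaves the size open) of none beyond the scatter. Compound 4 is estimated at 30000 nM, with a range from 8000 nM to 100000 nM.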

Compound 4, half-maximal effective concentration: > 30000 nM
Compound 4: no number, only a limit; the forecaster's own chance of this, stated with the estimate: 80%; the middle value sits exactly at the limit.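

In this assay the steps from compound 1, compound 2 and compound 3 to compound 4 cannot be read; all four values are limits. The compounds shown leave open whether in this assay any of these four would give a number, and whether bromo and fluoro on the shared core differ at all.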